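The compounds below may be only part of what the source reports. "The series", "measured", "known", "first", "only" and "open" are said of these compounds alone.

Measured compounds:
Compound 1 `Fc1ccc(COc2cccc(-c3cn([C@@H]4CN5CCC4CC5)nn3)c2)cc1` gives 537 nM in an assay on HEK293 cells for displacement of a labelled ligand from Neuronal acetylcholine receptor; alpha4/beta2 (Homo sapiens), read by scintillation counting, with a stated time of 120 min; a higher number here means a weaker inhibitor, a lower number a stronger inhibitor.
Compound 2 `FCCOc1cccc(-c2cn([C@H]3CN4CCC3CC4)nn2)c1` gives 7050 nM in this assay.
Compound 3 `FCCOc1cccc(-c2cn(C3CN4CCC3CC4)nn2)c1` gives 1960 nM in this assay.

Compound 3 stands second highest of the three numbers: compound 1 sits a step lower and compound 2 a step higher, both steps beyond the scatter. Compound 4 `FCCOc1cccc(-c2cn([C@@H]3CN4CCC3CC4)nn2)c1` differs from compound 3 by the two compounds have the same atoms and bonds; at least one stereo element is drawn with a configuration in one of them and without one in the other: 1 of 3 stereo elements differ; a stereocentre at a saturated ring carbon is drawn without a configuration in compound 3 and S in compound 4. Compound 3 is thus the mixture of two configurations at that ring carbon, compound 2 is one of them and compound 4 the other.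

Going by the values given here, the one measured step that differs in a single place bears directly on this: the step of a 3.6-fold lower number from compound 2 to compound 3 (0.56 log units; beyond the scatter). Its cause is plain from the fact that one of compounds 2 and 3 is drawn with a defined configuration and the other without, at the place where they differ, the configuration drawn in one and not in the other. Because the step of a 3.6-fold lower number from compound 2 to compound 3 (0.56 log units; beyond the scatter) moved to a lower number when the defined configuration of compound 2 was replaced by the mixture, the remaining configuration in compound 4 is expected to carry the stronger binding of the mixture, and a further modest move to a lower number is expected.

For compound 4 the expected step is a 1.8-fold lower number from compound 3 to compound 4 (0.25 log units; within the scatter). Compound 4 is therefore estimated at 1100 nM in this assay, with a range from 500 nM to 2500 nM.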

Compound 4, inhibition constant: 1260 nM
The estimate for compound 4 lay 1.1-fold (0.06 log units) below the measured number; the measured number falls inside the stated range.
By their numbers in this assay, from the lowest: compound 1; then compounds 4 and 3 (each within the scatter of the next); then compound 2.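

With both single configurations now available, the ring carbon can be judged directly: in this assay, going from R to S gives a 5.6-fold lower number from compound 2 to compound 4 (0.75 log units; beyond the scatter), so the configuration at this position changes the number beyond the scatter, and the comparison is clean for this reason: the fact that one of compounds 2 and 4 is drawn with a defined configuration and the other without, at the place where they differ The mixture and the S form, however, are not separated in this assay, with the step being a 1.6-fold lower number from compound 3 to compound 4 (0.19 log units; within the scatter), which lies within the scatter. Compound 4 also gives a comparison in which only the group on the chain changes, fluoromethyl in place of 4-fluorophenyl, and this is a 2.3-fold higher number from compound 1 to compound 4 (0.37 log units; beyond the scatter), so the larger 4-fluorophenyl ether holds the lower number by a modest step beyond the scatter.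

From the compounds shown here alone, whether the configuration at the ring carbon counts for as much with 4-fluorophenyl on the chain stays open. Also open, going by these compounds, is how the number would move if the fluorine of the fluoroethyl chain gave way to a hydroxyl group or an amine, or if a longer chain took its place.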